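The source may hold more compounds than are shown below. What is called first, only, known or untested is meant among the compounds shown, and "the series" means these compounds.

In a functional assay on HepG2 cells (Homo sapiens) for cytotoxicity, read by MTT assay, with a stated time of 48 h (on this read-out lower numbers stand for stronger inhibition and higher numbers for weaker inhibition), compound 3 `C=CCSc1nnc(CCC)n1N1C(=O)c2ccccc2C1=O` gives only a limit of the assay, > 200000 nM. Compound 1 `C=CCSc1nnc(CC)n1N1C(=O)c2ccccc2C1=O` likewise gives a limit, > 200000 nM. Compound 2 `CCOC(=O)CSc1nnc(CC)n1N1C(=O)c2ccccc2C1=O` also gives a limit, > 200000 nM. All three values therefore sit at the limit of > 200000 nM in this assay, at which 3 of the 3 values shown sit. Compound 4 `CCCc1nnc(SC)n1N1C(=O)c2ccccc2C1=O` differs from compound 3 by hydrogen in place of vinyl on a saturated chain carbon bound to a sulfur, which reads as allyl to methyl, or allylsulfanyl to methylsulfanyl. The measured steps on the same chain are a step that the two limits leave unreadable from compound 1 to compound 2 and a step that the two limits leave unreadable from compound 1 to compound 3; neither has a readable size, since both of their ends sit at the limit of > 200000 nM in this assay, at which 3 of the 3 values shown sit. For the measured compounds named here, no measured step thus gives a readable size for this change. The expected step in this assay is a number no higher from compound 3 to compound 4 (the limit leaves the size open), nothing beyond the scatter. Compound 4 is expected to give 200000 nM, within 100000 nM to 400000 nM, most likely again only as a limit.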

Compound 4, half-maximal inhibitory concentration: > 200000 nM
Compound 4: no number, only a limit (the forecaster's own chance of this, stated with the estimate: 85%); the middle value lies on the limit itself.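

The step between compound 3 and compound 4 cannot be read, because each gives only a limit and no number: the limit of > 200000 nM in this assay, at which 4 of the 4 values shown sit. The compounds shown leave open how strongly any of them acts on these cells, and whether changing allyl to methyl makes any difference.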